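The source may hold more compounds than are shown below. What is called first, only, known or untested is meant among the compounds shown, and "the series" means these compounds.

Measured so far:
Compound 1, `N[C@H](CN(C(=O)[C@@H]1C[C@H]1c1ccccc1)c1ccc(-c2ccccc2)cc1)C1CCCCC1`: 0.66 nM
Compound 2, `NC1(CN(C(=O)[C@@H]2C[C@H]2c2ccccc2)c2ccc(-c3ccccc3)cc2)CCCC1`: 0.57 nM
Compound 3, `CC[C@H](C)[C@H](N)CN(C(=O)[C@@H]1C[C@H]1c1cccc(C)c1)c1ccc(-c2ccccc2)cc1`: 1200 nM

These three compounds were tested in a functional assay for agonist activity at G protein-coupled receptor 88 (Homo sapiens), read by HTRF and cAMP accumulation; a higher number here means that more compound is needed for the effect, a lower number that less compound is needed. Compound 3 gives the highest number of the three, so it needs the most compound for the effect; compound 1 sits nearest to it, and compound 2 furthest, both gaps well beyond the scatter. For the measured compounds named here, the one measured step, a 1.2-fold lower number from compound 1 to compound 2 (0.06 log units; within the scatter), concerns only the amine-bearing side chain and lies within the scatter.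

Compound 4, `CC[C@H](C)[C@H](N)CN(C(=O)[C@@H]1C[C@H]1c1ncccn1)c1ccc(-c2ccccc2)cc1`, differs from compound 3 at a different place: pyrimidin-2-yl in place of 3-methylphenyl on a saturated ring carbon. Going by the values given here, no measured step touches the group on the three-membered ring, so the step from compound 3 to compound 4 in this assay has no direct precedent here. The step at the side chain says nothing about this position. With no guide, the expectation is no step beyond the scatter in either direction, and the range must be wide. Compound 4 is therefore estimated at 1500 nM, with a range from 300 nM to 8000 nM, which corresponds to an expected step of a 1.3-fold higher number from compound 3 to compound 4 (0.10 log units; within the scatter).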

Compound 4, half-maximal effective concentration: 130 nM
The estimate for compound 4 lay 12-fold (1.06 log units) above the measured number; measured number outside the range, below it.
By their numbers in this assay, from the lowest: compounds 2 and 1 (each within the scatter of the next); then compound 4; then compound 3.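

In this assay, for the compounds shown here, the group on the three-membered ring turns out to matter: pyrimidin-2-yl in place of 3-methylphenyl gives a 9.2-fold lower number from compound 3 to compound 4 (0.97 log units; beyond the scatter), the first measured evidence that this position responds to a change, as the earlier step concerned only the amine-bearing side chain. The change swaps a ring of carbon only, with 0 hydrogen-bond acceptors, for a ring with 2 hetero atoms and 2 hydrogen-bond acceptors, and it also removes the methyl group, so this single step cannot show which of these differences accounts for the lower number. Nothing available here explains the shift.

The compounds shown leave open whether pyridin-2-yl, with a single ring nitrogen, or pyrimidin-5-yl, with the same two ring nitrogens placed differently, would give a step of similar size. Going by these compounds, it also remains open whether pyrimidin-2-yl would have a comparable effect alongside the side chains of compound 1 and compound 2, which carry 2-phenylcyclopropyl rather than 2-(3-methylphenyl)cyclopropyl.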